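Flipping One Ring Stereocentre in a Prostaglandin Analogue Series

This account rests on a few compounds, and the source may have more. Where it says the series, first, only, none or still open, it means among the compounds named here.

Compound 1, `O=C(O)CCC1=CC[C@@H]2[C@@H](/C=C/[C@@H](O)COc3ccccc3)[C@H](O)C[C@@H]2OC1`: 2700 nM
Compound 2, `O=C(O)CC[C@@H]1CC[C@@H]2[C@@H](/C=C/[C@@H](O)COc3ccccc3)[C@H](O)C[C@@H]2OC1`: 870 nM

Both compounds were tested in a functional assay on CHO cells for agonist activity at prostaglandin E2 receptor EP3 subtype (Homo sapiens), read by fluorescence and calcium flux; a lower number here means that less compound is needed, a higher number that more compound is needed for the effect. Compound 2 stands at the lowest of the two numbers, with 870 nM. Compound 1 gives 2700 nM, and the gap between these two values lies beyond the usual scatter of repeated measurements, so compound 2 is the more potent of the pair on this evidence.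

Compound 3, `O=C(O)CC[C@H]1CC[C@@H]2[C@@H](/C=C/[C@@H](O)COc3ccccc3)[C@H](O)C[C@@H]2OC1`, has not yet been measured. It carries the same atoms and bonds as compound 2 and differs from it only in how one centre is drawn: the two compounds have the same atoms and bonds and differ only in configuration as drawn: 1 of 7 stereo elements differ; a stereocentre at a saturated ring carbon is drawn S in compound 2 and R in compound 3. Going by the values given here, no pair of measured compounds shows what this kind of inversion does in this assay, so its effect cannot be read off the numbers at hand, and the direction is open. The expectation for compound 3 is a modest rise in the number, a 2.3-fold higher number from compound 2 to compound 3 (0.36 log units; beyond the scatter). The estimated value for compound 3 is 2000 nM, expected to fall between 500 nM and 8000 nM.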

Compound 3, half-maximal effective concentration: 4800 nM
Compound 3: the middle estimate sits 2.4-fold (0.38 log units) below what was measured, and the stated range covers the measured number.
By their numbers in this assay, from the lowest: compound 2; then compounds 1 and 3 (each within the scatter of the next).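

In this assay, inverting one saturated ring carbon from S in compound 2 to R in compound 3 gives a 5.5-fold higher number from compound 2 to compound 3 (0.74 log units; beyond the scatter), the first measured effect of such an inversion in this series. The change is modest, yet it lies beyond the scatter, so the configuration drawn at this carbon does matter, and of these two compounds the S form needs less compound for the effect. Because no atom or bond changes between the two compounds, the shift can be assigned to this single centre alone, which the earlier values could not do: the fact that compounds 2 and 3 differ only in the configuration as drawn

Why this inversion raises the number remains unknown, since a difference in configuration records the size and direction of the shift but not its mechanism, and only one of the stereo elements has been tested in this way. The compounds shown also leave open what a methyl group or a fluorine on this ring carbon would do, and whether the preference for the S form would hold with an amide in place of the carboxylic acid.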